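A Cyclic Sulfonamide Replaces the Isopropylamino Group

The compounds below may be only part of what the source reports. "The series", "measured", "known", "first", "only" and "open" are said of these compounds alone.

Compound 3 `Cc1ccc(S(=O)(=O)NC(C)C)cc1C#Cc1cc(Cl)ccc1OCC(=O)O` was examined in a functional assay on cells for antagonist activity at prostaglandin D2 receptor 2 (Homo sapiens), read by flow cytometry, with a stated time of 10 min (on this read-out higher numbers stand for weaker inhibition and lower numbers for stronger inhibition), where compound 3 gives 250 nM. For the measured compounds named here, that is the highest of the three numbers measured so far. Compound 2 `Cc1ccc(S(=O)(=O)N(C)C(C)C)cc1C#Cc1cc(Cl)ccc1OCC(=O)O` gives 140 nM, and compound 1 `COCCN(C)S(=O)(=O)c1ccc(C)c(C#Cc2cc(Cl)ccc2OCC(=O)O)c1` gives 77 nM. The two neighbours of compound 3 lie at different distances: a 1.8-fold higher number from compound 2 to compound 3 (0.25 log units; within the scatter), whereas a 3.2-fold higher number from compound 1 to compound 3 (0.51 log units; beyond the scatter). Between the first two compounds, a 1.8-fold higher number from compound 1 to compound 2 (0.26 log units; within the scatter).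

Compound 4 `Cc1ccc(S(=O)(=O)N2CCCCC2C)cc1C#Cc1cc(Cl)ccc1OCC(=O)O` alters compound 3 at a single place: 2-methylpiperidin-1-yl in place of isopropylamino on a sulfonyl sulfur. Going by the values given here, of the measured steps, the one from compound 2 to compound 3 bears most directly, as it too concerns a hydrogen against a methyl on the sulfonamide nitrogen, and it stayed within the scatter. Compound 4 likewise carries no hydrogen on that nitrogen, so the step from compound 3 to compound 4 is expected to run toward a lower number, of small to modest size, comparable to what the steps from compound 3 back to compound 2 and compound 1 show. In this assay compound 4 is expected to give 120 nM, within a range from 40 nM to 350 nM. The expected step is then a 2.1-fold lower number from compound 3 to compound 4 (0.32 log units; beyond the scatter).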

Compound 4, half-maximal inhibitory concentration: 310 nM
Estimate against measurement, compound 4: 2.6-fold (0.41 log units) below, within the range that was stated.
By their numbers in this assay, from the lowest: compounds 1, 2, 3 and 4 (each within the scatter of the next, the first and the last beyond it).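

Closing the substituent on the sulfonyl sulfur into a 2-methylpiperidin-1-yl ring removes the hydrogen-bond donor of isopropylamino and adds heavy atoms, yet in this assay this gives a 1.2-fold higher number from compound 3 to compound 4 (0.09 log units; within the scatter) and so does not separate the two compounds. Compound 2 and compound 1 also carry no hydrogen on the sulfonamide nitrogen, but a 2.2-fold higher number from compound 2 to compound 4 (0.35 log units; beyond the scatter) and a 4.0-fold higher number from compound 1 to compound 4 (0.60 log units; beyond the scatter), both beyond the scatter, so the absence of that hydrogen does not by itself bring compound 4 level with either of them, and the groups on the nitrogen matter here even when it is fully substituted. Nothing available accounts for why the ring stands apart from the open chains of compound 1 and compound 2.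

What the compounds shown leave open is how a piperidin-1-yl ring without the methyl, a pyrrolidin-1-yl ring or a morpholin-4-yl ring would stand on this sulfonyl sulfur. Also open, from the compounds shown here alone, is whether the methoxy group at the end of the chain in compound 1 could be exchanged for a hydroxyl group or an amine.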